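The compounds below may be only part of what the source reports. "The series", "measured", "known", "first", "only" and "open" are said of these compounds alone.

Measured compounds:
- compound 1 `CCN(CC)S(=O)(=O)c1ccc(S(=O)(=O)N2CCC[C@@H](C(=O)N3CCC(OC)CC3)C2)cc1`: 50 nM
- compound 2 `CCN(CC)S(=O)(=O)c1ccc(S(=O)(=O)N2CCC[C@@H](C(=O)NC3CCOCC3)C2)cc1`: 1350 nM
- compound 3 `CCN(CC)S(=O)(=O)c1ccc(S(=O)(=O)N2CCC[C@@H](C(=O)N3CCC(COC)CC3)C2)cc1`: 50 nM

In a functional assay on MIA PaCa-2 cells (Homo sapiens) for inhibition, read by MTT assay, with a stated time of 3 days (a lower number here means a stronger inhibitor, a higher number a weaker inhibitor), compound 3 gives 50 nM. Compound 3 stands level with compound 1 at the digits shown, the two together giving the lowest numbers of the three, with no change at the digits printed from compound 1 to compound 3 (within the scatter). Compound 2 stands furthest away: a 27-fold lower number from compound 2 to compound 3 (1.43 log units; beyond the scatter).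

Compound 4 `CCN(CC)S(=O)(=O)c1ccc(S(=O)(=O)N2CCC[C@@H](C(=O)N3CC[C@H](OC)C3)C2)cc1` has not been measured. Its change from compound 3 is 3-methoxypyrrolidin-1-yl in place of 4-(methoxymethyl)piperidin-1-yl on a carbonyl carbon. Two of the measured steps bear on it. The step of no change at the digits printed from compound 1 to compound 3 (within the scatter) shows that swapping methoxy for methoxymethyl on the saturated ring carbon leaves the number unchanged. The step of a 27-fold lower number from compound 2 to compound 3 (1.43 log units; beyond the scatter) shows that the large loss comes when the ring-bonded amide of compound 3 is replaced by the (oxan-4-yl)amino group, not from the nature of the ether. Within the data shown here, compound 4 keeps a ring-bonded amide and an ether, so in this assay no step beyond the scatter is expected, though the ring contraction has no measured counterpart, leaving room for a modest drift. The expected step is a 1.4-fold higher number from compound 3 to compound 4 (0.15 log units; within the scatter). Compound 4 is therefore estimated at 70 nM, within 25 nM to 250 nM.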

Compound 4, half-maximal inhibitory concentration: 460 nM
The estimate for compound 4 lay 6.6-fold (0.82 log units) below the measured number; measured number outside the range, above it.
By their numbers in this assay, from the lowest: compounds 1 and 3 (each within the scatter of the next); then compound 4; then compound 2.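

In this assay, among these compounds, the earlier compounds suggested that a ring-bonded amide carrying an ether would be enough to hold the number, but the 3-methoxypyrrolidin-1-yl group does not hold it: the change gives a 9.2-fold higher number from compound 3 to compound 4 (0.96 log units; beyond the scatter) and likewise a 9.2-fold higher number from compound 1 to compound 4 (0.96 log units; beyond the scatter). So at this carbonyl carbon, the six-membered rings of the two piperidin-1-yl groups and the five-membered ring of compound 4 are not interchangeable, even though the methoxy and methoxymethyl swap between the two piperidines left the number unmoved; yet the five-membered ring still does better than the (oxan-4-yl)amino group, with a 2.9-fold lower number from compound 2 to compound 4 (0.47 log units; beyond the scatter), which places this change at an intermediate level rather than at the full loss. Nothing available here accounts for this loss.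

Going by these compounds, the step joins a smaller ring, a shorter substituted group and a defined stereocentre, so it remains open which of these carries the change. The 3-methoxypiperidin-1-yl group, the 3-(methoxymethyl)pyrrolidin-1-yl group and the mirror-image form of the 3-methoxypyrrolidin-1-yl group would each separate one of these from the others.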